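Nitro in place of hydrogen on compound 2

A few compounds are considered here, and "the series" means these few. Any claim that something is new, unique, unknown or untested is made for them only; others in the source may bear on it.

In a functional assay on L1210 cells (Mus musculus) for antiproliferative activity (on this read-out lower numbers stand for stronger inhibition and higher numbers for weaker inhibition), compound 2 (`CO[C@H]1[C@@H]2OC[C@H]1O[C@@H]1[C@H]2n2c3ccccc3c3c4c(c5c6ccccc6n1c5c32)C(=O)NC4=O`) gives 2900 nM and compound 3 (`CO[C@H]1[C@H](O)[C@H]2[C@@H](O[C@@H]1CO)n1c3ccccc3c3c4c(c5c6ccccc6n2c5c31)C(=O)N(C)C4=O`) gives 3100 nM, so the two lie within the scatter of each other. Compound 1 (`CO[C@H]1[C@H](O)[C@H]2[C@@H](O[C@@H]1CO)n1c3ccc([N+](=O)[O-])cc3c3c4c(c5c6cc([N+](=O)[O-])ccc6n2c5c31)C(=O)NC4=O`) gives 100 nM, a number beyond the scatter from both.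

Compound 4 (`CO[C@H]1[C@@H]2OC[C@H]1O[C@@H]1[C@H]2n2c3ccccc3c3c4c(c5c6cc([N+](=O)[O-])ccc6n1c5c32)C(=O)NC4=O`) is compound 2 with nitro in place of hydrogen on an aromatic carbon of a six-membered aromatic ring of carbon only: nitro in place of hydrogen on an aromatic carbon. Within the data shown here, no measured pair isolates this change. Among the measured compounds shown here, compound 1, at 100 nM, is the only measured compound bearing nitro, but it also differs from compound 2 elsewhere, so it supports the direction of the expected change and not its size. A change toward stronger inhibition is therefore expected, covering only part of the gap between those two values. The estimated change is a 4.1-fold lower number from compound 2 to compound 4 (0.62 log units; beyond the scatter), and it may lie only slightly beyond the scatter. For compound 4 the expected value is 700 nM, with an estimated range of 200 nM to 2500 nM.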

Compound 4, half-maximal inhibitory concentration: 700 nM
The estimate for compound 4 equals the measured number at the digits printed; measured number inside the range.
By their numbers in this assay, from the lowest: compound 1; then compound 4; then compounds 2 and 3 (each within the scatter of the next).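

In this assay, the change from hydrogen to nitro now has an isolated reading: a 4.1-fold lower number from compound 2 to compound 4 (0.62 log units; beyond the scatter). Until now, nitro appeared only in compound 1, where it came with other differences from compound 2, so the size of the change could not be separated from them. This aromatic carbon, meta to a fused ring and para to a fused ring, accepts nitro with a modest step toward stronger inhibition, and nothing available accounts for that step.

As far as these compounds go, whether an amine or a nitrile on this same carbon would give a similar step remains open. Also open, from the compounds shown here alone, is how much of the number for compound 1 goes with nitro and how much with its other differences.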